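The compounds below may be only part of what the source reports. "The series", "measured", "known", "first", "only" and "open" are said of these compounds alone.

Measured so far:
compound 1 `COc1ccc(F)cc1CNCCCNc1ccnc2cc(C3CCCCC3)ccc12`: 4200 nM
compound 2 `COc1cccc(Oc2ccc3c(NCCCNCc4cc(F)ccc4OC)ccnc3c2)c1`: 14500 nM
compound 3 `COc1ccc(F)cc1CNCCCNc1ccnc2cc(Cc3ccc(F)cc3)ccc12`: 4200 nM

In a physicochemical assay for solubility, with a stated time of 18 h, at pH 7.4 (on this read-out higher numbers stand for higher solubility and lower numbers for lower solubility), compound 2 gives 14500 nM, the highest of the three numbers. Its two neighbours lie beyond the scatter: a 3.5-fold higher number from compound 1 to compound 2 (0.54 log units; beyond the scatter), and a 3.5-fold lower number from compound 2 to compound 3 (0.54 log units; beyond the scatter). Both of those steps swap the group that sits on an aromatic carbon of the shared core, while the rest of each molecule is kept.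

Compound 4 `COc1cccc(Oc2ccc3c(NCCCNCc4cccc(OC)c4O)ccnc3c2)c1` is built differently. It keeps the group of compound 2 on that aromatic carbon and instead changes the other end of the molecule: 2-hydroxy-3-methoxyphenyl in place of 5-fluoro-2-methoxyphenyl on a saturated chain carbon bound to an amine nitrogen. Going by the values given here, none of the measured steps alters this part, so there is no direct precedent among the three compounds for what such a swap does in this assay.

With nothing to point either way, the expected step is one within the scatter, a 1.0-fold higher number from compound 2 to compound 4 (0.01 log units; within the scatter). Compound 4 is therefore estimated at 15000 nM, with a range from 6000 nM to 40000 nM.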

Compound 4, solubility: 14500 nM
The estimate for compound 4 lay 1.0-fold (0.01 log units) above the measured number; the measured number falls inside the stated range.
By their numbers in this assay, from the lowest: compounds 1 and 3 (each within the scatter of the next); then compounds 2 and 4 (each within the scatter of the next).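

The earlier compounds shown here changed only the group on the aromatic carbon of the shared core, and two of those three steps lay beyond the scatter. Going by these compounds alone, this result is the first view of the other end of the molecule, where 2-hydroxy-3-methoxyphenyl in place of 5-fluoro-2-methoxyphenyl on a saturated chain carbon bound to an amine nitrogen gives no change at the digits printed from compound 2 to compound 4 (within the scatter) in this assay, even though the entering group carries a hydrogen-bond donor and the leaving group carries none. No measurement on hand explains this outcome.

As far as these compounds go, whether the same swap behaves alike with the cyclohexyl group of compound 1 or the 4-fluorobenzyl group of compound 3 stays open. Also open, from the compounds shown here alone, is what a more different group at this place, such as a carboxylic acid or a piperidine, would do to the read-out.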